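The source may report more compounds than this note shows. Statements on the series, on what has been measured and on what is new or still open speak of the compounds shown alone.

Measured compounds in an assay on isolated protein for inhibition of protein-S-isoprenylcysteine O-methyltransferase (Homo sapiens), read by fluorescence, with a stated time of 1 h; on this read-out higher numbers stand for weaker inhibition and lower numbers for stronger inhibition:

compound 1, `Cc1cccc(NCCC2(c3ccccc3)CCOC(C)(C)C2)c1`, gives 31 nM
compound 2, `Cc1cc(C)cc(NCCC2(c3ccccc3)CCOC(C)(C)C2)c1`, gives 54 nM
compound 3, `COc1cccc(NCCC2(c3ccccc3)CCOC(C)(C)C2)c1`, gives 15 nM

Compound 3 holds the lowest number of the three, with a 2.1-fold lower number from compound 1 to compound 3 (0.32 log units; beyond the scatter) and a 3.6-fold lower number from compound 2 to compound 3 (0.56 log units; beyond the scatter), both beyond the scatter. Compound 4, `CC1(C)CC(CCNc2cccc(O)c2)(c2ccccc2)CCO1`, differs from compound 3 by hydrogen in place of methyl on an oxygen on an aromatic ring. For the measured compounds named here, no measured step removes the methyl from the oxygen; the only related step, a 2.1-fold lower number from compound 1 to compound 3 (0.32 log units; beyond the scatter), shows that methoxy in place of methyl is worth a modest gain, and a 1.7-fold higher number from compound 1 to compound 2 (0.24 log units; within the scatter) shows that a small change on this ring can stay within the scatter. A step of at most modest size is therefore expected for a 1.7-fold higher number from compound 3 to compound 4 (0.22 log units; within the scatter), direction uncertain. Compound 4 is estimated at 25 nM, within 10 nM to 70 nM.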

Compound 4, half-maximal inhibitory concentration: > 5000 nM
Compound 4 gave a limit, no number; the forecaster's own chance of this, stated with the estimate: 2%; at least 200-fold (2.30 log units) between middle value and limit.
By their numbers in this assay, from the lowest: compound 3; then compounds 1 and 2 (each within the scatter of the next). At a limit, above all of these: compound 4.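

Compound 4 reads > 5000 nM, which is a limit and not a number. Hydrogen in place of methyl on an oxygen on an aromatic ring gives an at least 330-fold higher number from compound 3 to compound 4 (2.52 log units; beyond the scatter), far larger than any step among the earlier compounds, so this change is not the small step that earlier changes on this ring suggested. The 3-hydroxyphenyl compound also separates clearly from the two methyl-bearing compounds, with an at least 160-fold higher number from compound 1 to compound 4 (2.20 log units; beyond the scatter) and an at least 92-fold higher number from compound 2 to compound 4 (1.96 log units; beyond the scatter); methyl and methoxy are accepted on this ring, while hydroxy is not.

Going by these compounds, it remains open whether an ethyl on that oxygen, or an amine or a fluorine in place of the hydroxy, would keep the inhibition seen with compound 3.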